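From compound 2 to compound 3: one group exchanged

This account rests on a few compounds, and the source may have more. Where it says the series, first, only, none or still open, it means among the compounds named here.

Compound 1 `CC(O)(CS(=O)(=O)c1cccc(S(F)(F)(F)(F)F)c1)C(=O)Nc1ccc([N+](=O)[O-])cc1C(F)(F)F` gives 100000 nM
Compound 2 `CC(O)(CS(=O)(=O)c1cccc(S(F)(F)(F)(F)F)c1)C(=O)Nc1ccc(S(F)(F)(F)(F)F)cc1` gives 24800 nM

In a functional assay on VCaP cells (Homo sapiens) for antiproliferative activity, read by propidium iodide staining, with a stated time of 96 h (on this read-out lower numbers stand for stronger inhibition and higher numbers for weaker inhibition), compound 2 gives 24800 nM and compound 1 gives 100000 nM so compound 2 holds the lower number of the two, by a gap beyond the usual scatter. Compound 3 `CC(O)(CS(=O)(=O)c1cccc(C(F)(F)F)c1)C(=O)Nc1ccc(S(F)(F)(F)(F)F)cc1` keeps everything in compound 2 except one group: a group of 4 heavy atoms (1 carbon, 3 fluorine; no ring) in place of a group of 6 heavy atoms (5 fluorine, 1 sulfur; no ring), on an aromatic carbon (on an aromatic carbon, meta to a large group). Among the compounds with values here, no measured pair shows this exchange, so the expected step is a 1.4-fold lower number from compound 2 to compound 3 (0.14 log units; within the scatter) in this assay and that means no change beyond the scatter. The expected value for compound 3 is 18000 nM with an estimated range of 5000 nM to 60000 nM (not yet a measurement).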

Compound 3, half-maximal inhibitory concentration: 32000 nM
Estimate against measurement, compound 3: 1.8-fold (0.25 log units) below, within the range that was stated.
By their numbers in this assay, from the lowest: compounds 2 and 3 (each within the scatter of the next); then compound 1.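

In this assay, placing trifluoromethyl on this aromatic carbon, meta to a large group, gives a 1.3-fold higher number from compound 2 to compound 3 (0.11 log units; within the scatter). Within the data shown here, this pair is the first to isolate a change at this position, and it shows that the two groups cannot be told apart here, even though trifluoromethyl has fewer heavy atoms. Nothing available explains this result. From the compounds shown here alone, whether an amine or a carboxylic acid at this aromatic carbon would shift the number beyond the scatter remains open. So does whether this exchange would behave the same way with a different group elsewhere on the core.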